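A few compounds are considered here, and "the series" means these few. Any claim that something is new, unique, unknown or untested is made for them only; others in the source may bear on it.

Compound 3, `COc1cccc(-c2ccc(C(=O)N(Cc3cccc(OCCCCCC(=O)O)c3)C(C)C)cc2)c1`, is one of three closely related amides that share a core and differ only in the group carried on one aromatic carbon of the outer ring. In an ADME assay on HEK293 cells (Homo sapiens) for cytotoxicity, read by CellTiter-Glo and resazurin assay, with a stated time of 72 h (on this read-out lower numbers stand for an effect already at smaller amounts and higher numbers for an effect only at larger amounts of compound), compound 3 gives only a limit, > 20900 nM, and no number. Compound 1, `CC(=O)c1cccc(-c2ccc(C(=O)N(Cc3cccc(OCCCCCC(=O)O)c3)C(C)C)cc2)c1`, likewise reaches only a limit in this assay, > 26000 nM. Compound 2, `CC(C)N(Cc1cccc(OCCCCCC(=O)O)c1)C(=O)c1ccc(-c2cccc(Oc3ccccc3)c2)cc1`, also stops at a limit in this assay, > 18700 nM. With three limits and no numbers, none of the steps among them can be read: a step that the two limits leave unreadable from compound 1 to compound 2, a step that the two limits leave unreadable from compound 1 to compound 3 and a step that the two limits leave unreadable from compound 2 to compound 3 all fall between limits (the limit of > 18700 nM in this assay, at which 1 of the 3 values shown sits, (the limit of > 20900 nM in this assay, at which 1 of the 3 values shown sits), (the limit of > 26000 nM in this assay, at which 1 of the 3 values shown sits)).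

Compound 4, `CC(C)N(Cc1cccc(OCCCCCC(=O)O)c1)C(=O)c1ccc(-c2cccc(OC(F)(F)F)c2)cc1`, differs from compound 3 by trifluoromethyl in place of methyl on an oxygen on an aromatic ring. The step from a methyl to a phenyl on this same oxygen, or to an acetyl on the ring, left no readable change, so nothing measured here points to a shift beyond the scatter for the trifluoromethyl. Compound 4 is therefore expected to show a step that the limit leaves unreadable from compound 3 to compound 4 in this assay, most likely ending at a limit once more. The estimate for compound 4 is 25000 nM, and the range for compound 4 runs from 10000 nM to 60000 nM.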

Compound 4, half-maximal effective concentration: > 26000 nM
Compound 4: only a limit was reported; the forecaster's own chance of this, stated with the estimate: 85%; middle value at least 1.0-fold (0.01 log units) away from the limit.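

In this assay compound 4 gives only a limit of > 26000 nM and no number. Among the compounds shown here, compound 1, compound 2 and compound 3 also stop at limits, so no step from any of them to compound 4 can be read. The compounds shown leave open at what concentration each would affect these cells, and whether acetyl, phenoxy, methoxy and trifluoromethoxy differ at all in this assay.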